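Flat response to chain growth in an alkoxy series

The source may report more compounds than this note shows. Statements on the series, on what has been measured and on what is new or still open speak of the compounds shown alone.

Measured so far in a functional assay on brain (Rattus norvegicus, strain Wistar) for inhibition; a lower number here means a stronger inhibitor, a higher number a weaker inhibitor
compound 1 (`CCCCOc1ccc(-c2c(C)[nH]c(=O)n2C)cc1`) gives 5100 nM
compound 2 (`CCCCCOc1ccc(-c2c(C)[nH]c(=O)n2C)cc1`) gives 4500 nM
compound 3 (`CCCCCCCCOc1ccc(-c2c(C)[nH]c(=O)n2C)cc1`) gives 4000 nM

Compound 3 stands level with compound 1 and compound 2 in this assay, with no gap beyond the scatter. The change to compound 4 (`CCCCCCCCCCCOc1ccc(-c2c(C)[nH]c(=O)n2C)cc1`) is further growth of the same chain: propyl in place of hydrogen on a saturated chain carbon, eight bonds along the chain from an oxygen on an aromatic ring and nothing else. Within the data shown here, three measured steps bear on it: a 1.1-fold lower number from compound 1 to compound 2 (0.05 log units; within the scatter), a 1.1-fold lower number from compound 2 to compound 3 (0.05 log units; within the scatter) and a 1.3-fold lower number from compound 1 to compound 3 (0.11 log units; within the scatter), all small. No step beyond the scatter is therefore expected in this assay, and no direction is favoured. The step expected is (a 1.1-fold lower number from compound 3 to compound 4 (0.02 log units; within the scatter)). Compound 4 is estimated at 3800 nM (1700 nM to 8500 nM).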

Compound 4, half-maximal inhibitory concentration: 9700 nM
Estimate against measurement, compound 4: 2.6-fold (0.41 log units) below; the whole stated range lies below it.
By their numbers in this assay, from the lowest: compounds 3, 2, 1 and 4 (each within the scatter of the next, the first and the last beyond it).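

In this assay, chain length at this position now registers: propyl in place of hydrogen, eight bonds along the chain from the oxygen on the aromatic ring, gives a modest step (a 2.4-fold higher number from compound 3 to compound 4 (0.38 log units; beyond the scatter)), and the longer comparison agrees (a 2.2-fold higher number from compound 2 to compound 4 (0.33 log units; beyond the scatter)). The flat run therefore does not extend to the longest chain, although the step from the butoxy compound stays within the scatter (a 1.9-fold higher number from compound 1 to compound 4 (0.28 log units; within the scatter)). No evidence at hand explains the turn.

Going by these compounds, whether a longer chain raises the number further remains open. So does how an amine or a carboxylic acid in place of the propyl would read.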